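This account rests on a few compounds, and the source may have more. Where it says the series, first, only, none or still open, it means among the compounds named here.

Measured so far in a functional assay on A549 cells (Homo sapiens) for antiproliferative activity, read by MTT assay, with a stated time of 72 h; a higher number here means a weaker inhibitor, a lower number a stronger inhibitor
- compound 1 `Cc1ccc(S(=O)(=O)NC(=N)N2CCN(c3cc4c(cc3F)c(=O)c(C(=O)O)cn4C3CC3)CC2)cc1` gives 71 nM
- compound 2 `CCn1cc(C(=O)O)c(=O)c2cc(F)c(N3CCN(C(=N)NS(=O)(=O)c4cccc(Cl)c4)CC3)cc21` gives 71 nM
- compound 3 `CCn1cc(C(=O)O)c(=O)c2cc(F)c(N3CCN(C(=N)NS(=O)(=O)c4ccccc4)CC3)cc21` gives 71 nM

Compound 1 stands level with compound 2 and compound 3 at the digits shown. Next is compound 4 `N=C(NS(=O)(=O)c1ccccc1C(F)(F)F)N1CCN(c2cc3c(cc2F)c(=O)c(C(=O)O)cn3C2CC2)CC1` with this change: 2-(trifluoromethyl)phenyl in place of 4-methylphenyl on a sulfonyl sulfur. Within the data shown here, the one measured step in the group on the sulfonyl sulfur is no change at the digits printed from compound 2 to compound 3 (within the scatter) and it involves hydrogen in place of chloro on an aromatic carbon. Among the measured compounds shown here, no trifluoromethyl compound has been measured, so this guide is weak. No step beyond the scatter is expected in this assay. The expected step is no change at the digits printed from compound 1 to compound 4 (within the scatter) on this estimate. Compound 4 is expected at 71 nM with an estimated range of 28 nM to 180 nM for now.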

Compound 4, half-maximal inhibitory concentration: 71 nM
Estimate against measurement, compound 4: no gap at the digits printed, and the stated range covers the measured number.
By their numbers in this assay, from the lowest: compounds 1, 2, 3 and 4 (each within the scatter of the next).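

In this assay the group on the sulfonyl sulfur now tolerates a larger exchange than hydrogen for chloro: 2-(trifluoromethyl)phenyl in place of 4-methylphenyl leaves the read-out within the scatter (no change at the digits printed from compound 1 to compound 4 (within the scatter)). The entering group has 10 heavy atoms against 7, and it brings fluorine to this position. No evidence on the cause of this result is available. 

Still open, going by these compounds, is whether a non-aromatic group on the sulfonyl sulfur, such as a butyl chain, would hold the value. On these data alone, a carboxylic acid or an amine on the phenyl ring is equally open.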